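Moving one hydroxyl group on the shared core

The compounds below may be only part of what the source reports. "The series", "measured", "known", "first", "only" and "open" are said of these compounds alone.

Measured compounds:
compound 1, `Oc1ccc(-c2cc(-c3cccs3)cc(-c3cccc(O)c3)n2)cc1`, 1890 nM
compound 2, `Oc1cccc(-c2cc(-c3ccccn3)cc(-c3cccc(O)c3)n2)c1`, 3610 nM

In a functional assay on DU-145 cells (Homo sapiens) for cytotoxicity, read by CCK-8 assay (on this read-out higher numbers stand for weaker inhibition and lower numbers for stronger inhibition), compound 2 gives the highest of the two numbers; compound 1 lies near it, and the gap between the two is within the scatter. Compound 3, `Oc1ccc(-c2cc(-c3ccccn3)cc(-c3cccc(O)c3)n2)cc1`, has not been measured. It differs from compound 2 by 4-hydroxyphenyl in place of 3-hydroxyphenyl on an aromatic carbon. For the measured compounds named here, no such step has been measured here, so the expected size rests on the two values alone. Compound 3 is expected to change little: the step of a 1.3-fold lower number from compound 2 to compound 3 (0.11 log units; within the scatter) should stay within the scatter. The value of compound 3 in this assay is estimated at 2800 nM, between 1200 nM and 6500 nM.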

Compound 3, half-maximal inhibitory concentration: 1980 nM
Compound 3: the middle estimate sits 1.4-fold (0.15 log units) above what was measured; the measured number falls inside the stated range.
By their numbers in this assay, from the lowest: compounds 1, 3 and 2 (each within the scatter of the next).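

In this assay, moving the hydroxyl group from 3-hydroxyphenyl to 4-hydroxyphenyl, on the aromatic carbon next to the ring nitrogen, gives a 1.8-fold lower number from compound 2 to compound 3 (0.26 log units; within the scatter) and so shows no clear preference between these two groups at this position. With 4-hydroxyphenyl held in place, pyridin-2-yl in place of thiophen-2-yl gives a 1.0-fold higher number from compound 1 to compound 3 (0.02 log units; within the scatter) and likewise leaves the number within the scatter. Nothing further is available to explain either result.

On these data alone, whether a methoxy group or an amine in place of this hydroxyl group would move the number beyond the scatter remains open.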